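Series notes: from compound 2 to compound 4

A few compounds are considered here, and "the series" means these few. Any claim that something is new, unique, unknown or untested is made for them only; others in the source may bear on it.

Of the compounds shown here, three have been measured in an assay on isolated protein for inhibition of Apoptosis regulator Bcl-2 (Homo sapiens), read by fluorescence polarization; on this read-out higher numbers stand for weaker inhibition and lower numbers for stronger inhibition. Compound 1 `O=C(O)c1ccc([N+](=O)[O-])c(COc2ccc(/C=C3\SC(=S)N(c4ccccc4)C3=O)cc2)c1` gives 9000 nM. Compound 2 `Cc1ccccc1N1C(=O)/C(=C/c2ccc(OCC(=O)Nc3ccc(C(=O)O)cc3)cc2)SC1=S` returns only a limit, > 10000 nM. Compound 3 `Cc1cccc(N2C(=O)/C(=C/c3ccc(OCc4ccc(C(=O)O)cc4)cc3)SC2=S)c1` likewise returns only a limit, > 10000 nM. Compound 2 thus stands at the limit of this assay, where two of the three values sit (the limit of > 10000 nM in this assay, at which 2 of the 3 values shown sit). Only compound 1 gives a number, and that number lies close to the same limit.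

Compound 4 `Cc1cccc(N2C(=O)/C(=C/c3ccc(OCC(=O)Nc4ccc(C(=O)O)cc4)cc3)SC2=S)c1` has not been measured. It differs from compound 2 by 3-methylphenyl in place of 2-methylphenyl on an amide-type nitrogen in a ring, in words 3-methylphenyl in place of 2-methylphenyl on an amide-type nitrogen in a ring. Going by the values given here, no measured step between two compounds differing in one place is available, so the expected size of this step in this assay can rest only on the values shown. Compound 3 carries the same 3-methylphenyl group and sits at the limit. Compound 2 sits at the limit as well. Nothing among these numbers points to a gain or a loss beyond the scatter. The expected step is therefore a step that the limit leaves unreadable from compound 2 to compound 4, none beyond the scatter. Compound 4 is estimated at 15000 nM, within a range of 6000 nM to 40000 nM, with a good chance that this assay again reports only a limit.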

Compound 4, inhibition constant: > 10000 nM
Compound 4 ended at the assay's limit; the forecaster's own chance of this, stated with the estimate: 75%; the middle value is on the limit's open side.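

In this assay compound 4 returns > 10000 nM, which is a limit and not a number. Compound 2 likewise returns a limit, > 10000 nM. No step can be read between compound 2 and compound 4. The compounds shown leave open whether 3-methylphenyl in place of 2-methylphenyl on the amide-type nitrogen changes inhibition at all.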